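This account rests on a few compounds, and the source may have more. Where it says the series, first, only, none or still open, it means among the compounds named here.

The measured compounds are:
Compound 1, `CS(=O)(=O)c1nn(Cc2nc3cc(Cl)ccc3n2CCCO)c2cnccc12`: > 100000 nM
Compound 2, `CS(=O)(=O)c1nn(Cc2nc3cc(Cl)ccc3n2CCC(O)C(F)(F)F)c2cnccc12`: > 100000 nM

In an ADME assay on HEp-2 cells (Homo sapiens) for cytotoxicity, with a stated time of 4 days (on this read-out lower numbers stand for higher toxicity in this test and higher numbers for lower toxicity in this test), compound 1 gives > 100000 nM, which is a limit of the assay rather than a number. In this assay compound 2 likewise gives > 100000 nM, again a limit and not a number. Compound 2 thus stands at the limit of > 100000 nM in this assay, at which 2 of the 2 values shown sit, and the step that the two limits leave unreadable from compound 1 to compound 2 cannot be read, since neither of its ends is a number. Compound 3, `CS(=O)(=O)c1nn(Cc2nc3cc(Cl)ccc3n2CCC(F)(F)F)c2cnccc12`, differs from compound 2 by trifluoromethyl in place of 2,2,2-trifluoro-1-hydroxyethyl on a saturated chain carbon, two bonds along the chain from an aromatic nitrogen. Among the compounds with values here, the one measured step alters the same saturated chain, but its size is not readable, so the data give no reading of how large a movement to expect in this assay, in either direction. With both measured compounds sitting at the limit, compound 3 is expected to behave the same way, with an estimated step that the limit leaves unreadable from compound 2 to compound 3 that means no change beyond the scatter. The estimate for compound 3 is 150000 nM, between 60000 nM and 400000 nM.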

Compound 3, half-maximal cytotoxic concentration: > 100000 nM
Compound 3: only a limit was reported; the forecaster's own chance of this, stated with the estimate: 80%; the middle value does not contradict the limit.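

Within the data shown here, compound 1, compound 2 and compound 3 all give a limit in this assay rather than a number, so no step among them can be read: the limit of > 100000 nM in this assay, at which 3 of the 3 values shown sit. From the compounds shown here alone, it remains open how far beyond that limit each compound lies, and whether these chain changes alter cytotoxicity at all.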